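Replacing the sulfamoylthiophene of compound 3 with a pyrimidine

A few compounds are considered here, and "the series" means these few. Any claim that something is new, unique, unknown or untested is made for them only; others in the source may bear on it.

Of the compounds shown here, three sharing one core have been measured. Compound 1, `O=C(CCCCCCc1ccccc1)c1ncc(-c2ccc([N+](=O)[O-])cc2)o1`, gives 50 nM in an assay (Rattus norvegicus) for inhibition of Fatty-acid amide hydrolase 1 (Homo sapiens); a lower number here means a stronger inhibitor, a higher number a weaker inhibitor. Compound 2, `Nc1ccc(-c2cnc(C(=O)CCCCCCc3ccccc3)o2)cc1`, gives 90 nM. Compound 3, `NS(=O)(=O)c1ccc(-c2cnc(C(=O)CCCCCCc3ccccc3)o2)s1`, gives 3 nM and stands lowest of the three; its steps to both others lie beyond the scatter, so it is the strongest inhibitor measured here. Compound 4, `O=C(CCCCCCc1ccccc1)c1ncc(-c2cncnc2)o1`, differs from compound 3 by pyrimidin-5-yl in place of 5-sulfamoylthiophen-2-yl on an aromatic carbon.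

For the measured compounds named here, two measured steps bear on this change, since both bring the group that now leaves: a 17-fold lower number from compound 1 to compound 3 (1.22 log units; beyond the scatter) and a 30-fold lower number from compound 2 to compound 3 (1.48 log units; beyond the scatter). Each time the 5-sulfamoylthiophen-2-yl entered, the number fell by a large step, so its departure is expected to send the number up, although pyrimidin-5-yl itself has not been measured and the size of the reverse step is uncertain. Compound 4 is therefore expected to give about 60 nM, between 15 nM and 250 nM. That estimate means a 20-fold higher number from compound 3 to compound 4 (1.30 log units; beyond the scatter) is expected.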

Compound 4, inhibition constant: 22 nM
The estimate for compound 4 lay 2.7-fold (0.44 log units) above the measured number; measured number inside the range.
By their numbers in this assay, from the lowest: compound 3; then compound 4; then compounds 1 and 2 (each within the scatter of the next).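

For the compounds shown here, the result shows that 5-sulfamoylthiophen-2-yl is not the only group on this aromatic carbon, next to the ring oxygen, that lowers the number in this assay over the substituted phenyl groups: pyrimidin-5-yl, a six-membered aromatic ring with 0 hydrogen-bond donors, gives a 4.1-fold lower number from compound 2 to compound 4 (0.61 log units; beyond the scatter) against 4-aminophenyl and a 2.3-fold lower number from compound 1 to compound 4 (0.36 log units; beyond the scatter) against 4-nitrophenyl. It still falls short of the sulfamoylthiophene, with a 7.3-fold higher number from compound 3 to compound 4 (0.87 log units; beyond the scatter) on this change. The unsubstituted pyrimidine therefore recovers part, but not all, of the drop seen with compound 3.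

The compounds shown leave open whether the sulfamoyl group or the thiophene ring carries that drop, and whether a sulfamoyl group, an amine or a carboxylic acid on the pyrimidine ring would close the remaining gap. No supporting measurement accounts for these differences.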